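The source may report more compounds than this note shows. Statements on the series, on what has been measured and on what is new or still open speak of the compounds shown alone.

Compound 1 `CC(C)n1ncc2c(C(=O)Nc3cccc(S(N)(=O)=O)c3)cc(-c3cccs3)nc21`: 25000 nM
Compound 2 `CC(C)n1ncc2c(C(=O)Nc3cncnc3)cc(-c3cccs3)nc21`: 20000 nM
Compound 3 `CC(C)n1ncc2c(C(=O)Nc3cc(C(N)=O)ccc3F)cc(-c3cccs3)nc21`: 25000 nM

In an ADME assay on LLC-MK2 cells (Macaca mulatta) for cytotoxicity, read by spectrophotometry and crystal violet staining, with a stated time of 4 days (a higher number here means that more compound is tolerated, a lower number that less compound is tolerated), compound 3 stands level with compound 1 at the digits shown, and all three values sit within the scatter of one another: a 1.3-fold lower number from compound 1 to compound 2 (0.10 log units; within the scatter), no change at the digits printed from compound 1 to compound 3 (within the scatter) and a 1.3-fold higher number from compound 2 to compound 3 (0.10 log units; within the scatter). Compound 4 `CC(C)n1ncc2c(C(=O)Nc3ccc(F)cc3F)cc(-c3cccs3)nc21` is not yet measured; it differs from compound 3 by 2,4-difluorophenyl in place of 5-carbamoyl-2-fluorophenyl on an amide-type nitrogen. Going by the values given here, no measured step exchanges the amide aryl for a group with no hydrogen-bond donors or acceptors, yet each exchange on the amide-type nitrogen so far left the number within scatter. The same is therefore expected here, with no change at the digits printed from compound 3 to compound 4 (within the scatter) small. Compound 4 is estimated at 25000 nM, with a range from 10000 nM to 60000 nM.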

Compound 4, half-maximal cytotoxic concentration: > 200000 nM
Compound 4 gave a limit, no number; the forecaster's own chance of this, stated with the estimate: 25%; at least 8.0-fold (0.90 log units) between middle value and limit.
By their numbers in this assay, from the lowest: compounds 2, 1 and 3 (each within the scatter of the next). At a limit, above all of these: compound 4.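

In this assay compound 4 gives a limit, not a number: the limit of > 200000 nM in this assay, at which 1 of the 4 values shown sits.

This makes the amide-type nitrogen a place where an exchange can move the reading beyond the scatter, with an at least 8.0-fold higher number from compound 3 to compound 4 (0.90 log units; beyond the scatter), an at least 10-fold higher number from compound 2 to compound 4 (1.00 log units; beyond the scatter) and an at least 8.0-fold higher number from compound 1 to compound 4 (0.90 log units; beyond the scatter). The entering 2,4-difluorophenyl has 0 hydrogen-bond donors and 0 hydrogen-bond acceptors, whereas the 5-carbamoyl-2-fluorophenyl it replaces has 1 of each.

As far as these compounds go, it remains open whether a plain phenyl or a pyridyl on this nitrogen would also reach such a limit. The compounds also cannot separate the loss of the carbamoyl group from the presence of the second fluorine.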